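The source may hold more compounds than are shown below. What is called first, only, known or untested is meant among the compounds shown, and "the series" means these compounds.

Series notes, carboxylic acid series with a shared core.

Of the compounds shown here, three have numbers so far. Compound 1 `CC(C)Oc1ccc(-c2cc(C(=O)O)nn2-c2ccccc2)cc1` gives 7000 nM in an assay for displacement of a labelled ligand from Apoptosis regulator Bcl-2 (Homo sapiens), read by fluorescence polarization, with a stated time of 30 min; on this read-out higher numbers stand for weaker inhibition and lower numbers for stronger inhibition. Compound 2 `CCOc1ccc(-c2cc(C(=O)O)nn2-c2ccc(Oc3ccccc3)cc2)cc1` gives 694 nM in this assay, and compound 3 `CC(C)Oc1ccc(-c2cc(C(=O)O)nn2-c2ccc(Oc3ccccc3)cc2)cc1` gives 932 nM. Compound 3 therefore stands second highest of the three numbers: the step from compound 2 is a 1.3-fold higher number from compound 2 to compound 3 (0.13 log units; within the scatter), while the step from compound 1 is a 7.5-fold lower number from compound 1 to compound 3 (0.88 log units; beyond the scatter), so compound 3 is clearly separated only from compound 1.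

The next compound, compound 4 `CC(C)Oc1ccc(-c2cc(C(=O)O)nn2-c2ccc(C(C)C)cc2)cc1`, differs from compound 3 in one place: isopropyl in place of phenoxy on an aromatic carbon. Going by the values given here, the only measured step touching this position is a 7.5-fold lower number from compound 1 to compound 3 (0.88 log units; beyond the scatter), which shows that a hydrogen at this carbon gives a markedly higher number than phenoxy. Isopropyl is neither hydrogen nor phenoxy; it brings no ring and no hydrogen-bond acceptor, and there is no measured step with a group of this kind at this position. The expectation is a number between those of compound 1 and compound 3, closer to compound 3, which corresponds to an estimated step of a 2.1-fold higher number from compound 3 to compound 4 (0.33 log units; beyond the scatter). Compound 4 is therefore expected to give about 2000 nM in this assay, with a range from 700 nM to 6000 nM.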

Compound 4, inhibition constant: 5250 nM
The estimate for compound 4 lay 2.6-fold (0.42 log units) below the measured number; the measured number falls inside the stated range.
By their numbers in this assay, from the lowest: compounds 2 and 3 (each within the scatter of the next); then compounds 4 and 1 (each within the scatter of the next).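

In this assay, isopropyl in place of phenoxy on this aromatic carbon, para to a large group, gives a 5.6-fold higher number from compound 3 to compound 4 (0.75 log units; beyond the scatter), so the lower number seen with phenoxy does not carry over to every group placed here. Isopropyl in place of hydrogen at the same carbon gives a 1.3-fold lower number from compound 1 to compound 4 (0.12 log units; within the scatter), which means that isopropyl and hydrogen cannot be told apart at this position, and that among the three groups shown here only phenoxy stands clear of hydrogen. Nothing on hand accounts for the difference between phenoxy and isopropyl at this carbon.

The compounds shown leave open whether the ring or the ether oxygen of phenoxy is what separates compound 3 from compound 4, a question on which a phenyl or a methoxy group at this carbon would bear. Also open, going by these compounds, is how an amine or a longer chain would read at this position, and whether a benzyloxy group would keep the lower number seen with phenoxy.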